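Replacing a 1-methylethenyl amide with a 2-carboxyethenyl amide

The compounds below may be only part of what the source reports. "The series", "measured", "known", "first", "only" and "open" are said of these compounds alone.

Compound 1 `C=CC(=O)Nc1cccc(-c2nc3ccccc3s2)c1` in an ADME assay on BJ cells (Homo sapiens) for inhibition, with a stated time of 72 h (on this read-out higher numbers stand for an effect only at larger amounts of compound and lower numbers for an effect already at smaller amounts), gives > 25000 nM, which is a limit of the assay rather than a number.
Compound 2 `C/C=C/C(=O)Nc1cccc(-c2nc3ccccc3s2)c1` in this assay gives > 25000 nM, again a limit.
Compound 3 `C=C(C)C(=O)Nc1cccc(-c2nc3ccccc3s2)c1` in this assay gives > 25000 nM, also a limit.

All three known values sit at the same limit (the limit of > 25000 nM in this assay, at which 3 of the 3 values shown sit), so compound 3 stands exactly where its two neighbours stand and cannot be placed above or below them. The measured steps a step that the two limits leave unreadable from compound 1 to compound 2, a step that the two limits leave unreadable from compound 1 to compound 3 and a step that the two limits leave unreadable from compound 2 to compound 3 are all unreadable for the same reason: both ends of each are limits. Compound 4 `O=C(O)/C=C/C(=O)Nc1cccc(-c2nc3ccccc3s2)c1` differs from compound 3 by 2-carboxyethenyl in place of 1-methylethenyl on a carbonyl carbon. The measured steps that bear on this change are exactly those three, since each of them swaps the group on the same carbonyl carbon, yet none of them gave a readable size; they show only that vinyl, prop-1-en-1-yl and 1-methylethenyl on this carbonyl carbon all stayed at the limit. The expectation for compound 4 is therefore that the step that the limit leaves unreadable from compound 3 to compound 4 has no readable direction and stays within what the limit can show. Compound 4 is estimated at 50000 nM, with a range from 20000 nM to 200000 nM.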

Compound 4, half-maximal effective concentration: > 25000 nM
Compound 4: only a limit was reported; the forecaster's own chance of this, stated with the estimate: 90%; the middle value lies beyond the limit too.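

In this assay compound 4 gives > 25000 nM and this is again a limit. For the compounds shown here, no step among compound 1, compound 2, compound 3 and compound 4 can be read, because both ends of each step are limits: the limit of > 25000 nM in this assay, at which 4 of the 4 values shown sit. Going by these compounds, how far each of these four compounds lies beyond that limit, and whether their carbonyl groups differ at all on this read-out, stays open.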